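Phenyl for Pentyl: Expected Effect on Antiproliferative Potency

The compounds below may be only part of what the source reports. "The series", "measured", "known", "first", "only" and "open" are said of these compounds alone.

Measured in a functional assay on A549 cells (Homo sapiens) for antiproliferative activity, read by MTT assay, with a stated time of 48 h; a higher number here means a weaker inhibitor, a lower number a stronger inhibitor:
- compound 1 `CCCCCCC1(O)C(=O)Nc2ccc(Nc3ccc(OC)cc3)cc21` gives 18600 nM
- compound 2 `COc1ccc(Nc2ccc3c(c2)C(O)(Cc2ccccc2)C(=O)N3)cc1` gives > 30000 nM, which is a limit of the assay rather than a number
- compound 3 `CCCCCCC1(O)C(=O)Nc2ccc(Nc3ccc(C)cc3)cc21` gives 12100 nM

Compound 2 differs from compound 1 by phenyl in place of pentyl on a saturated chain carbon bound to a saturated ring carbon, and the step was an at least 1.6-fold higher number from compound 1 to compound 2 (0.20 log units; that floor lies within the scatter); the value of compound 2 sits at the limit of > 30000 nM in this assay, at which 1 of the 3 values shown sits. The two cores differ by methyl in place of methoxy on an aromatic carbon, a step of a 1.5-fold lower number from compound 1 to compound 3 (0.19 log units; within the scatter). Compound 4 `Cc1ccc(Nc2ccc3c(c2)C(O)(Cc2ccccc2)C(=O)N3)cc1` differs from compound 3 by phenyl in place of pentyl on a saturated chain carbon bound to a saturated ring carbon, at the same place as before, so this is the same change. The step from compound 3 to compound 4 in this assay is expected to be a 2.3-fold higher number from compound 3 to compound 4 (0.36 log units; beyond the scatter), resting on an at least 1.6-fold higher number from compound 1 to compound 2 (0.20 log units; that floor lies within the scatter). Compound 4 is estimated at 28000 nM, between 15000 nM and 60000 nM.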

Compound 4, half-maximal inhibitory concentration: 4100 nM
For compound 4 the middle estimate is 6.8-fold (0.83 log units) above the measured one; measured number outside the range, below it.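

In this assay, phenyl in place of pentyl gives a 3.0-fold lower number from compound 3 to compound 4 (0.47 log units; beyond the scatter), while methyl in place of methoxy, read on the two phenyl compounds, gives an at least 7.3-fold lower number from compound 2 to compound 4 (0.86 log units; beyond the scatter). The phenyl-for-pentyl change therefore does not carry over unchanged from one core to the other: the same change on two cores in this assay, an at least 1.6-fold higher number (0.20 log units; that floor lies within the scatter) from compound 1 to compound 2 and a 3.0-fold lower number (0.47 log units; beyond the scatter) from compound 3 to compound 4, at least 4.7-fold (0.67 log units) apart, beyond the scatter of two such steps Compound 2 gives > 30000 nM, a limit of the assay and not a number, and two cores alone do not show why the steps part or how a third core would respond.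

Still open, going by these compounds, is whether a longer chain than pentyl would follow either step. Also open, on these data alone, is how a pyridine ring in place of phenyl, or an amine in place of methyl, would read in this assay.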